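From fluoro to methoxy: a small step expected

A few compounds are considered here, and "the series" means these few. Any claim that something is new, unique, unknown or untested is made for them only; others in the source may bear on it.

Three compounds share one core and differ only in what sits on the aromatic ring of their side chain: compound 1 `COc1ccc2nc(C)cc(NCc3ccccc3)c2c1`, compound 2 `COc1ccc2nc(C)cc(NCc3ccc(C)cc3)c2c1` and compound 3 `COc1ccc2nc(C)cc(NCc3ccccc3F)c2c1`. In a functional assay on MCF-10A cells (Homo sapiens) for antiproliferative activity, with a stated time of 48 h (on this read-out lower numbers stand for an effect already at smaller amounts and higher numbers for an effect only at larger amounts of compound), compound 1 gives 25900 nM, compound 2 gives 18800 nM and compound 3 gives 14000 nM. Compound 3 therefore stands within the usual scatter of both others, and these numbers do not rank the three.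

The next compound, compound 4 `COc1ccc2nc(C)cc(NCc3ccccc3OC)c2c1`, carries methoxy in place of fluoro on an aromatic carbon, ortho to a large group: methoxy in place of fluoro on an aromatic carbon.

Going by the values given here, three measured steps bear on this change. Methyl in place of hydrogen gave a 1.4-fold lower number from compound 1 to compound 2 (0.14 log units; within the scatter), fluoro in place of hydrogen gave a 1.9-fold lower number from compound 1 to compound 3 (0.27 log units; within the scatter), and going from one substituted compound to the other gave a 1.3-fold lower number from compound 2 to compound 3 (0.13 log units; within the scatter). All three stayed within the scatter. None of them places a methoxy group on the ring, so they offer only indirect guidance and no clear direction. The expected change is a 1.2-fold higher number from compound 3 to compound 4 (0.08 log units; within the scatter), and no step beyond the scatter is expected in this assay. For compound 4 the estimated value is 17000 nM, with an expected range from 8000 nM to 35000 nM.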

Compound 4, half-maximal effective concentration: 25200 nM
The estimate for compound 4 lay 1.5-fold (0.17 log units) below the measured number, within the range that was stated.
By their numbers in this assay, from the lowest: compounds 3, 2, 4 and 1 (each within the scatter of the next).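

Methoxy in place of fluoro on this aromatic carbon, ortho to a large group, gives a 1.8-fold higher number from compound 3 to compound 4 (0.26 log units; within the scatter) in this assay and so adds a first direct reading of methoxy on the ring. Set against the ring that carries only hydrogen at this carbon, methoxy gives a 1.0-fold lower number from compound 1 to compound 4 (0.01 log units; within the scatter) and so joins methyl and fluoro as a further substituent whose step stays within the scatter, even though fluoro has 1 heavy atom and 0 hydrogen-bond acceptors while methoxy has 2 heavy atoms and 1 hydrogen-bond acceptor. No measurement of any property of these groups accompanies the numbers, so they stand here without an explanation.

The compounds shown leave open whether any group at this carbon can produce a step beyond the scatter, as every step among them stays within it. An amine or a carboxylic acid in the same place, or a longer chain in place of methoxy, would test that in this assay and show whether this carbon matters for the read-out at all.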